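Swapping aryl groups on the ring nitrogen: a flat series

This account rests on a few compounds, and the source may have more. Where it says the series, first, only, none or still open, it means among the compounds named here.

Measured so far in an assay on CHO cells for displacement of a labelled ligand from adenosine receptor A1 (Homo sapiens), read by scintillation counting, with a stated time of 120 min, tested at 10 uM; on this read-out lower numbers stand for less inhibition and higher numbers for more inhibition at the one concentration tested (going by the name of the read-out):
compound 1 `CC(C)N1CCN(Cc2csc(N)c2C(=O)c2ccc(Cl)cc2)CC1`, 0%
compound 2 `Nc1scc(CN2CCN(c3cc(Cl)cc(Cl)c3)CC2)c1C(=O)c1ccc(Cl)cc1`, 1%
compound 3 `Nc1scc(CN2CCN(c3ccc(F)cc3F)CC2)c1C(=O)c1ccc(Cl)cc1`, 1%

Compound 2 stands level with compound 3 and within the usual scatter of compound 1. The earlier steps shown here were all small: a number 1 percentage points higher from compound 1 to compound 2 (within the scatter), a number 1 percentage points higher from compound 1 to compound 3 (within the scatter) and no change at the digits printed from compound 2 to compound 3 (within the scatter). Compound 4 `Nc1scc(CN2CCN(c3cccc(F)c3F)CC2)c1C(=O)c1ccc(Cl)cc1` differs from compound 2 by 2,3-difluorophenyl in place of 3,5-dichlorophenyl on an amine nitrogen in a ring. Since every replacement of the group on the ring nitrogen so far has left this assay unmoved, the same is expected here, and a step of no change at the digits printed from compound 2 to compound 4 (within the scatter) is the estimate, that is, none beyond the scatter. Compound 4 is therefore expected to give about 1%, in a range from 0% to 10%.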

Compound 4, a percentage reported as inhibition, at one concentration (the size of the read-out at that concentration, not a potency): 0%
For compound 4 the middle estimate is 1 percentage points above the measured one; measured number inside the range.
By their numbers in this assay, from the lowest: compounds 1, 4, 2 and 3 (each within the scatter of the next).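

In this assay, 2,3-difluorophenyl on the ring nitrogen gives a number 1 percentage points lower from compound 2 to compound 4 (within the scatter), a number 1 percentage points lower from compound 3 to compound 4 (within the scatter) and no change at the digits printed from compound 1 to compound 4 (within the scatter). Going by these compounds alone, the step from 2,4-difluorophenyl is the first comparison here of two difluorophenyl groups that differ only in where their fluorines sit, and it does not separate them. No supporting data bear on this result.

Going by these compounds, whether a different kind of group on this nitrogen, such as a benzyl group, a carboxylic acid or a longer alkyl chain, would move the number beyond the scatter remains open.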